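The compounds below may be only part of what the source reports. "The series", "measured", "known", "first", "only" and "open" are said of these compounds alone.

Measured in a functional assay on the whole organism for antagonist activity, with Mus musculus as the target; a higher number here means that more compound is needed for the effect, a lower number that less compound is needed:
- Compound 1 `Cc1cncn1CC#CCN1C(=O)CCC1C`: 14.2 mg/kg
- Compound 2 `CC(=O)N(C)CC#CCN1CCCC1`: > 10 mg/kg, a limit
- Compound 3 `COC(=O)N(C)CC#CCN1CCCC1`: > 10 mg/kg, a limit

Compound 3 has no exact number, only the limit > 10 mg/kg. It stands with one other compound at the limit of > 10 mg/kg in this assay, at which 2 of the 3 values shown sit. Only compound 1 has an exact number, and its structure differs from compound 3 in more than one place.

Compound 4 `COC(=O)N(C)CC#CCN(C)C` has not yet been measured. It carries dimethylamino in place of pyrrolidin-1-yl on a saturated chain carbon bound to a triple-bonded carbon.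

Within the data shown here, the only measured step, a step that the two limits leave unreadable from compound 2 to compound 3, changes the group on a carbonyl carbon instead, and it has no readable size to carry over. Among the measured compounds shown here, no measured step tests this exchange, so no shift beyond the scatter in this assay is expected in either direction. The expected step is a step that the limit leaves unreadable from compound 3 to compound 4. This expectation rests on the limit of compound 3, > 10 mg/kg. Another limit instead of an exact number would be no surprise. For compound 4 the estimated value is 18 mg/kg, with an expected range from 6 mg/kg to 60 mg/kg.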

Compound 4, dose for half-maximal effect: > 30 mg/kg
Compound 4 ended at the assay's limit (the forecaster's own chance of this, stated with the estimate: 60%); middle value at least 1.6-fold (0.22 log units) from the limit.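

Among these compounds, compound 3 and compound 4 each have only a limit and no exact number, so the exchange of pyrrolidin-1-yl for dimethylamino gives no step that can be read. The compounds shown leave open whether this exchange changes the dose needed, and in which direction.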